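Selenium methylation in a quinazoline-type cytotoxicity series

A few compounds are considered here, and "the series" means these few. Any claim that something is new, unique, unknown or untested is made for them only; others in the source may bear on it.

Working notes on compound 2 and its methylated analogue. Compound 2 `[SeH]c1nc(NCc2ccccc2)c2ccccc2n1` carries a free selenium hydrogen on the shared core. In a functional assay on HT-29 cells (Homo sapiens) for cytotoxicity, read by MTT assay, with a stated time of 72 h (a higher number here means that more compound is tolerated, a lower number that less compound is tolerated), compound 2 gives only a limit, > 100000 nM, and no number. Compound 1 `COc1ccc(CNc2nc([Se]C)nc3ccccc23)cc1`, a related methylselenium analogue with a methoxybenzyl group, likewise gives only a limit in this assay, > 100000 nM. Both values shown therefore sit at the same limit, (the limit of > 100000 nM in this assay, at which 2 of the 2 values shown sit), so compound 2 cannot be ranked against compound 1 beyond that.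

Compound 3 `C[Se]c1nc(NCc2ccccc2)c2ccccc2n1` is not yet measured. It differs from compound 2 by methyl in place of hydrogen on a selenium. Within the data shown here, no step between measured compounds is available for this change. Given that compound 1, which already carries the methylselenium group, gives > 100000 nM, compound 3 is expected to stay at the limit, with the step of a number no higher from compound 2 to compound 3 (the limit leaves the size open) being none beyond the scatter. Compound 3 is estimated at 100000 nM, with a range from 30000 nM to 300000 nM.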

Compound 3, concentration lethal to 50% of the cells: > 100000 nM
Compound 3 ended at the assay's limit; the forecaster's own chance of this, stated with the estimate: 85%; the middle value lies on the limit itself.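

No step can be read among compound 1, compound 2 and compound 3 in this assay, because all three values are limits and not numbers: the limit of > 100000 nM in this assay, at which 3 of the 3 values shown sit.

The compounds shown leave open whether methyl in place of hydrogen on a selenium, or hydrogen in place of methoxy on an aromatic carbon, changes cytotoxicity at all.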